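Swapping an amide for a carbamoyl link in a kinase-type series

The source may hold more compounds than are shown below. What is called first, only, known or untested is meant among the compounds shown, and "the series" means these compounds.

Compound 1 `COc1cc(-c2nn(-c3cccc(NC(=O)c4cccc(C(F)(F)F)c4)c3)cc2-c2ccncc2)ccc1Cl` is tested in a functional assay on HT-29 cells (Homo sapiens) for inhibition, read by sulforhodamine B assay, with a stated time of 48 h (a higher number here means a weaker inhibitor of growth, a lower number a stronger inhibitor of growth), where compound 1 gives 1390 nM. Two companions share much of its shape but carry a hydroxyl where compound 1 has a methoxy, and join their terminal aryl group through a carbamoyl linker rather than a carbonyl. In this assay compound 2 `O=C(Nc1cccc(-n2cc(-c3ccncc3)c(-c3ccc(Cl)c(O)c3)n2)c1)Nc1cc(C(F)(F)F)cc(C(F)(F)F)c1` gives 746 nM, and compound 3 `O=C(Nc1cccc(-n2cc(-c3ccncc3)c(-c3ccc(Cl)c(O)c3)n2)c1)Nc1ccc(Cl)c(C(F)(F)F)c1` gives 1280 nM. The number for compound 1 is the largest of the three, yet its gaps to compound 3 and to compound 2 both lie within the usual scatter of repeated measurements, so the three cannot be separated on these data.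

Compound 4 `COc1cc(-c2nn(-c3cccc(NC(=O)Nc4ccc(Cl)c(Cl)c4)c3)cc2-c2ccncc2)ccc1Cl` has not yet been measured. It differs from compound 1 in one place: (3,4-dichlorophenyl)amino in place of 3-(trifluoromethyl)phenyl on a carbonyl carbon. The core, the methoxy and the pyridyl arm are kept.

Within the data shown here, with no directly comparable pair of measured compounds, the expectation leans on compounds 2 and 3, whose carbamoyl-type linkers give numbers close to that of compound 1. Compound 4 is therefore expected to show a step of a 1.4-fold lower number from compound 1 to compound 4 (0.14 log units; within the scatter) that stays within the scatter, with no clear direction. The estimate for compound 4 in this assay is 1000 nM, expected to fall between 400 nM and 2500 nM.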

Compound 4, concentration for 50% growth inhibition: 1240 nM
The estimate for compound 4 lay 1.2-fold (0.09 log units) below the measured number, within the range that was stated.
By their numbers in this assay, from the lowest: compounds 2, 4, 3 and 1 (each within the scatter of the next).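

In this assay, among these compounds, putting (3,4-dichlorophenyl)amino in place of 3-(trifluoromethyl)phenyl on the carbonyl carbon gives a 1.1-fold lower number from compound 1 to compound 4 (0.05 log units; within the scatter), the first comparison here between two compounds that differ in only one place. It shows that this position can go from a (3-(trifluoromethyl)phenyl)carbonyl group to a (3,4-dichlorophenyl)carbamoyl group, gaining a hydrogen-bond donor and swapping trifluoromethyl for two chlorines, with no readable shift in growth inhibition. The single swap changes the linker and the ring substituents together, so it cannot tell whether each change alone does nothing or whether two opposing changes cancel, and no measurement shown here offers an explanation for the result.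

Every compound shown keeps an aromatic ring at the end of this linker, so it remains open whether the number would move with a morpholine, a carboxylic acid or a simple alkyl chain there. The compounds shown also include no pair that differs only in methoxy versus hydroxyl, so the part played by that group remains unknown.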